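This account rests on a few compounds, and the source may have more. Where it says the series, first, only, none or still open, it means among the compounds named here.

Two compounds of this series have numbers in a functional assay on Huh-7 cells (Homo sapiens) for cytotoxicity, read by CCK-8 assay, with a stated time of 72 h; on this read-out lower numbers stand for stronger inhibition and higher numbers for weaker inhibition. Compound 1 `C=CCn1c(=O)/c(=C\c2cccc(F)c2)[nH]c(=O)/c1=C\c1ccccc1OC` gives 27200 nM in this assay. For the measured compounds named here, compound 2 `C=CCn1c(=O)/c(=C\c2cccc(Br)c2)[nH]c(=O)/c1=C\c1ccccc1OC` gives 2300 nM in this assay, and it stands lowest of the two numbers; the only neighbour is compound 1, and the step of a 12-fold lower number from compound 1 to compound 2 (1.07 log units; beyond the scatter) sets it apart beyond the scatter.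

Compound 3 `C=CCn1c(=O)/c(=C\c2cccc(C)c2)[nH]c(=O)/c1=C\c1ccccc1OC` has not yet been measured in this assay. It differs from compound 2 by methyl in place of bromo on an aromatic carbon. Going by the values given here, the one measured step that bears on this position is a 12-fold lower number from compound 1 to compound 2 (1.07 log units; beyond the scatter), which shows that the group on this aromatic carbon moves the number by a large amount within this pair. Among the compounds with values here, no measured compound carries methyl at that position, so the size of the step for compound 3 is not fixed by the data; a methyl at this carbon is taken to give a number above that of compound 2 but not back at the number of compound 1. The step from compound 2 to compound 3 is therefore expected to be a 2.6-fold higher number from compound 2 to compound 3 (0.42 log units; beyond the scatter), a rise of the number. Compound 3 is estimated at 6000 nM in this assay, within a range from 2500 nM to 15000 nM.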

Compound 3, half-maximal inhibitory concentration: 21400 nM
Compound 3: middle estimate off by 3.6-fold (0.55 log units), on the low side, and the stated range ends below it.
By their numbers in this assay, from the lowest: compound 2; then compounds 3 and 1 (each within the scatter of the next).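

In this assay, replacing bromo with methyl on this aromatic carbon gives a 9.3-fold higher number from compound 2 to compound 3 (0.97 log units; beyond the scatter) and removes most of the advantage of the 3-bromophenyl compound, so the low number of compound 2 is not a general result of moving away from fluoro. Methyl and fluoro are not separated at this position, as the comparison gives a 1.3-fold lower number from compound 1 to compound 3 (0.10 log units; within the scatter) and places compound 1 and compound 3 together, leaving bromo as the only one of the three groups set apart from the other two beyond the scatter. The three compounds therefore show a single favourable group rather than a graded series, and no measurement on hand accounts for the difference between bromo and the other two groups.

Three groups on one aromatic carbon cannot show whether chloro, iodo, methoxy, trifluoromethyl, an amine or a carboxylic acid would fall with bromo or with methyl and fluoro. As far as these compounds go, it also remains open whether the gap between the 3-bromophenyl and 3-methylphenyl compounds persists when other parts of the shared core are changed, or in cell lines other than the one used here.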